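The source may hold more compounds than are shown below. What is called first, only, known or untested is meant among the compounds shown, and "the series" means these compounds.

Working notes on the series. Compound 1 `COc1cncc(-c2c(C)nn(-c3nc(-c4ccc(Cl)c(Cl)c4)c(SC(C)C)s3)c2C(=O)O)c1` gives 21000 nM in a functional assay on BJAB cells (Homo sapiens) for antiproliferative activity, with a stated time of 4 days; a lower number here means that less compound is needed, a higher number that more compound is needed for the effect. Compound 2 `Cc1ccccc1-c1c(C)nn(-c2nc(-c3ccc(Cl)c(Cl)c3)c(SC(C)C)s2)c1C(=O)O` gives 5500 nM in this assay. Compound 3 `Cc1nn(-c2nc(-c3ccc(Cl)c(Cl)c3)c(SC(C)C)s2)c(C(=O)O)c1-c1cncc(C#N)c1` gives 20000 nM in this assay, the second highest of the three numbers; compound 1 lies within the scatter of it, while compound 2 lies beyond it, as a 3.6-fold higher number from compound 2 to compound 3 (0.56 log units; beyond the scatter) shows.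

Compound 4 `Cc1nn(-c2nc(-c3ccc(Cl)c(Cl)c3)c(SC(C)C)s2)c(C(=O)O)c1-c1cccc(Cl)c1` differs from compound 3 at one place: 3-chlorophenyl in place of 5-cyanopyridin-3-yl on an aromatic carbon. Going by the values given here, two measured steps bear on this swap of a six-membered aromatic ring with 1 hetero atom for one of carbon only. In one direction the series gave a 3.8-fold lower number from compound 1 to compound 2 (0.58 log units; beyond the scatter); in the other it gave a 3.6-fold higher number from compound 2 to compound 3 (0.56 log units; beyond the scatter). Both steps are modest and both put the carbon-only ring at the lower number. A modest drop is therefore expected for compound 4, on the order of a 3.3-fold lower number from compound 3 to compound 4 (0.52 log units; beyond the scatter). The estimate for compound 4 in this assay is 6000 nM, with a range from 2500 nM to 15000 nM.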

Compound 4, half-maximal effective concentration: 13600 nM
The estimate for compound 4 lay 2.3-fold (0.36 log units) below the measured number; the measured number falls inside the stated range.
By their numbers in this assay, from the lowest: compound 2; then compounds 4, 3 and 1 (each within the scatter of the next).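

At this place on the five-membered aromatic ring, 3-chlorophenyl does not reproduce the lower number seen with 2-methylphenyl in this assay: the series gives a 1.5-fold lower number from compound 3 to compound 4 (0.17 log units; within the scatter) and a 1.5-fold lower number from compound 1 to compound 4 (0.19 log units; within the scatter), so a carbon-only ring in place of a ring with 1 hetero atom is not enough on its own to separate these groups. The two carbon-only rings themselves differ, with a 2.5-fold higher number from compound 2 to compound 4 (0.39 log units; beyond the scatter), which makes compound 4 the exception to the earlier trend and leaves compound 2 alone beyond the scatter of the other three. No measured data at hand explain why compound 2 stands apart.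

Open, from the compounds shown here alone, is whether 2-chlorophenyl or 3-methylphenyl would read with compound 2 or with compound 4, which would separate the effect of the group from that of its place on the ring. Also open, going by these compounds, is how unsubstituted phenyl or an aminophenyl group would read here.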